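Piperazine nitrogen substituent in a triazine cytotoxicity series

The compounds below may be only part of what the source reports. "The series", "measured", "known", "first", "only" and "open" are said of these compounds alone.

Measured compounds:
compound 1 `COc1ccc(CN2CCN(c3nc(Nc4ccc(C#N)c(C(F)(F)F)c4)nc(Oc4ccnc5ccccc45)n3)CC2)c(OC)c1OC` — > 100000 nM (limit)
compound 2 `CC(C)N1CCN(c2nc(Nc3ccc(C#N)c(C(F)(F)F)c3)nc(Oc3ccnc4ccccc34)n2)CC1` — > 100000 nM (limit)

In a functional assay on DU-145 cells (Homo sapiens) for cytotoxicity, read by sulforhodamine B assay, with a stated time of 48 h (on this read-out higher numbers stand for weaker inhibition of growth and lower numbers for stronger inhibition of growth), compound 1 gives > 100000 nM, which is a limit of the assay and not a number. In this assay compound 2 likewise gives > 100000 nM, again a limit. Compound 2 thus stands at the same place as compound 1, namely at the limit of > 100000 nM in this assay, at which 2 of the 2 values shown sit, and nothing in the numbers shown separates the two.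

Compound 3 `N#Cc1ccc(Nc2nc(Oc3ccnc4ccccc34)nc(N3CCN(c4ccccc4F)CC3)n2)cc1C(F)(F)F` is still to be measured in this assay. It differs from compound 2 in 2-fluorophenyl in place of isopropyl on an amine nitrogen in a ring. For the measured compounds named here, no measured pair shows the effect of this change, so no step size can be read off. The step from compound 2 to compound 3 is expected to be a number no higher from compound 2 to compound 3 (the limit leaves the size open), no change beyond the scatter, because both measured values sit at the limit of > 100000 nM in this assay, at which 2 of the 2 values shown sit. Compound 3 is estimated at 100000 nM, in the range 20000 nM to 500000 nM, with a strong chance that only a limit is reported.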

Compound 3, concentration for 50% growth inhibition: > 100000 nM
Compound 3 ended at the assay's limit; the forecaster's own chance of this, stated with the estimate: 75%; the middle value lies on the limit itself.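

No step can be read from compound 2 to compound 3, because both values are limits of the assay and not numbers: the limit of > 100000 nM in this assay, at which 3 of the 3 values shown sit.

The compounds shown leave open whether isopropyl and 2-fluorophenyl on the amine nitrogen in a ring differ in growth inhibition at all.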